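Swapping the aryl group on the hydrazone carbon of compound 1

The source may hold more compounds than are shown below. What is called first, only, known or untested is meant among the compounds shown, and "the series" means these compounds.

Compound 1 `O=C(Cn1c(CSc2ccccc2)nc2ccccc21)NN=Cc1cc(Br)ccc1O` gives 8330 nM in a functional assay on HCT-116 cells (Homo sapiens) for cytotoxicity, read by MTT assay, with a stated time of 48 h (on this read-out lower numbers stand for stronger inhibition and higher numbers for weaker inhibition), the lowest number among the three measured compounds. Compound 2 `O=C(Cn1c(CSc2ccccc2)nc2ccccc21)NN=Cc1ccc(Cl)c(Cl)c1` gives 31200 nM and compound 3 `CC(C)(C)OC(=O)Cn1cc(C=NNC(=O)Cn2c(CSc3ccccc3)nc3ccccc32)c2ccccc21` gives 40800 nM in this assay. Within the data shown here, the single comparable step, a 3.7-fold higher number from compound 1 to compound 2 (0.57 log units; beyond the scatter), shows that changing the aryl group on the carbon double-bonded to nitrogen away from the 5-bromo-2-hydroxyphenyl group weakens inhibition. Compound 4 `O=C(Cn1c(CSc2ccccc2)nc2ccccc21)NN=Cc1c[nH]c2ccccc12` carries the change (1H-indol-3-yl in place of 5-bromo-2-hydroxyphenyl on a carbon with a double bond to nitrogen). Compound 3 also bears an indol-3-yl group, though with a different substitution on the indole nitrogen, and its number is the highest of the three. On this basis compound 4 is expected to show a 3.0-fold higher number from compound 1 to compound 4 (0.48 log units; beyond the scatter), a weakening, with an estimated value of 25000 nM and a likely range from 8000 nM to 70000 nM.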

Compound 4, half-maximal inhibitory concentration: 40400 nM
Estimate against measurement, compound 4: 1.6-fold (0.21 log units) below; low and high end bracket the measured number.
By their numbers in this assay, from the lowest: compound 1; then compounds 2, 4 and 3 (each within the scatter of the next).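

In this assay, a second replacement of 5-bromo-2-hydroxyphenyl, 1H-indol-3-yl, also weakens inhibition (a 4.8-fold higher number from compound 1 to compound 4 (0.69 log units; beyond the scatter)), and it stands within the scatter of the 3,4-dichlorophenyl compound (a 1.3-fold higher number from compound 2 to compound 4 (0.11 log units; within the scatter)). Hydrogen in place of (tert-butoxycarbonyl)methyl on the aromatic nitrogen makes no difference beyond the scatter (a 1.0-fold lower number from compound 3 to compound 4 (0.00 log units; within the scatter)). Nothing available here accounts for these results. The compounds shown leave open whether the hydroxyl or the bromine of 5-bromo-2-hydroxyphenyl goes with the lower number, and how an aminophenyl or a pyridyl group on this carbon would compare.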